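Shifting the hydroxy group: compound 2 to compound 3

The compounds below may be only part of what the source reports. "The series", "measured", "known", "first", "only" and "open" are said of these compounds alone.

Measured in a functional assay on Hs-578T cells (Homo sapiens) for inhibition, read by sulforhodamine B assay, with a stated time of 48 h; a higher number here means a weaker inhibitor of growth, a lower number a stronger inhibitor of growth:
compound 1 `O=C(Cc1csc2nc(-c3ccc(Br)cc3)cn12)N/N=C/c1ccccc1`: 16200 nM
compound 2 `O=C(Cc1csc2nc(-c3ccc(Br)cc3)cn12)N/N=C/c1ccccc1O`: 13500 nM

Compound 2 and compound 1 lie within the scatter of each other, so neither stands apart on these two numbers. Compound 3 `O=C(Cc1csc2nc(-c3ccc(Br)cc3)cn12)N/N=C/c1ccc(O)cc1` keeps the core of compound 2 and changes one group: 4-hydroxyphenyl in place of 2-hydroxyphenyl on a carbon with a double bond to nitrogen. Among the compounds with values here, the only measured step that bears on this is hydroxy in place of hydrogen on an aromatic carbon, a 1.2-fold lower number from compound 1 to compound 2 (0.08 log units; within the scatter). Within the data shown here, that step stays within the scatter, and no measured compound yet carries 4-hydroxyphenyl. No step beyond the scatter is therefore expected in this assay. The expected step is a 1.0-fold higher number from compound 2 to compound 3 (0.02 log units; within the scatter). The estimate for compound 3 is 14000 nM, with an expected range of 7000 nM to 28000 nM.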

Compound 3, concentration for 50% growth inhibition: 23400 nM
Compound 3: middle estimate off by 1.7-fold (0.22 log units), on the low side; the measured number falls inside the stated range.
By their numbers in this assay, from the lowest: compounds 2, 1 and 3 (each within the scatter of the next).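

In this assay, 4-hydroxyphenyl in place of 2-hydroxyphenyl on a carbon with a double bond to nitrogen gives a 1.7-fold higher number from compound 2 to compound 3 (0.24 log units; within the scatter), and hydroxy in place of hydrogen on an aromatic carbon gives a 1.4-fold higher number from compound 1 to compound 3 (0.16 log units; within the scatter). Both hydroxyphenyl groups therefore stay within the scatter of the unsubstituted compound, and moving the hydroxy group produces no step beyond it. Nothing available accounts for these numbers.

Still open, as far as these compounds go, is whether a methoxy group, an amine or a carboxylic acid on this ring would give a step beyond the scatter.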